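Replacing an aryl amine with a cyclohexyl amine

The source may report more compounds than this note shows. Statements on the series, on what has been measured and on what is new or still open speak of the compounds shown alone.

The three measured compounds share one core and differ only in the group carried on the amine nitrogen. Compound 1 `O=C1C(Nc2ccc(Br)cc2)=CC(=O)c2c1nc1n2[C@H]2OC[C@@H](O)[C@H]2OC1` gives 2020 nM in a functional assay on MGC-803 cells (Homo sapiens) for inhibition, read by sulforhodamine B assay; on this read-out higher numbers stand for weaker inhibition and lower numbers for stronger inhibition. For the measured compounds named here, compound 2 `O=C1C=C(Nc2ccccc2F)C(=O)c2c1nc1n2[C@H]2OC[C@@H](O)[C@H]2OC1` gives 2080 nM, and compound 3 `O=C1C=C(Nc2ccc(Br)cc2)C(=O)c2c1nc1n2[C@H]2OC[C@@H](O)[C@H]2OC1` gives 1010 nM; compound 1 lies within the scatter of both, while the one step that is beyond the scatter, a 2.1-fold lower number from compound 2 to compound 3 (0.31 log units; beyond the scatter), is modest.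

Compound 4 `O=C1C(NC2CCCCC2)=CC(=O)c2c1nc1n2[C@H]2OC[C@@H](O)[C@H]2OC1` is reached from compound 1 by cyclohexyl in place of 4-bromophenyl on an amine nitrogen. Going by the values given here, the only measured step swaps one aromatic ring for another; none of the measured compounds carries a non-aromatic ring on the amine nitrogen, so no measured step bears directly on this change. Given that the only known step is modest and that the three measured values span little, compound 4 is expected to stay near compound 1, with a 1.2-fold higher number from compound 1 to compound 4 (0.09 log units; within the scatter) not beyond the scatter. Compound 4 is therefore estimated at 2500 nM, within 900 nM to 7000 nM.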

Compound 4, half-maximal inhibitory concentration: > 8000 nM
Compound 4: only a limit was reported; the forecaster's own chance of this, stated with the estimate: 5%; middle value at least 3.2-fold (0.50 log units) away from the limit.
By their numbers in this assay, from the lowest: compounds 3, 1 and 2 (each within the scatter of the next, the first and the last beyond it). At a limit, above all of these: compound 4.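

Until now only aromatic rings had stood on the amine nitrogen, and their values lay close together. Cyclohexyl brings the first non-aromatic ring to this place, and the change away from 4-bromophenyl is not neutral in this assay, giving an at least 3.9-fold higher number from compound 1 to compound 4 (0.59 log units; beyond the scatter). Compound 4 is reported only as a limit, so this step has a floor but no measured size: the limit of > 8000 nM in this assay, at which 1 of the 4 values shown sits.

The compounds shown do not separate the change from aromatic to non-aromatic ring from the departure of the bromine, and a plain phenyl, a benzyl or a cyclopentyl group on the same nitrogen would bear on that. They also leave open whether cyclohexyl would read the same way on the arrangement of the core carried by compound 3.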